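Fluoro gives way to hydrogen on the shared core

A few compounds are considered here, and "the series" means these few. Any claim that something is new, unique, unknown or untested is made for them only; others in the source may bear on it.

In an ADME assay on microsomes from liver (Rattus norvegicus) for metabolic stability, read by LC-MS, using NADPH, with a stated time of 30 min, tested at 1 uM (on this read-out higher numbers stand for a more stable compound and lower numbers for a less stable compound), compound 2 (`C=CC(=O)Nc1cc(Nc2ncc(F)c(Nc3ccccc3S(=O)(=O)N(C)C)n2)c(OC)cc1N(C)CCN(C)C`) gives 7% remaining, while compound 1 (`C=CC(=O)Nc1cc(Nc2ncc(I)c(Nc3ccccc3S(=O)(=O)N(C)C)n2)c(OC)cc1N(C)CCN(C)C`) gives 12% remaining. These two numbers lie within the usual scatter of each other, so compound 2 cannot be ranked apart from compound 1.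

The unmeasured compound 3 (`C=CC(=O)Nc1cc(Nc2nccc(Nc3ccccc3S(=O)(=O)N(C)C)n2)c(OC)cc1N(C)CCN(C)C`) has hydrogen in place of fluoro on an aromatic carbon of compound 2 (hydrogen in place of fluoro on an aromatic carbon) and is otherwise the same. Among the measured compounds shown here, one measured step bears on this spot, where fluoro replaces iodo: a number 5 percentage points lower from compound 1 to compound 2 (within the scatter) stays within the scatter. For the measured compounds named here, no compound with hydrogen at this spot has been measured yet, so this single pair is only a partial guide.

Going by the values given here, no step beyond the scatter is expected in this assay because a number 5 percentage points lower from compound 1 to compound 2 (within the scatter) was the only change seen at this spot. The expected step is a number 1 percentage points higher from compound 2 to compound 3 (within the scatter) and it stays within the usual scatter. For compound 3 the estimated value is 8% remaining, with an expected range from 3% to 18% in repeated measurements.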

Compound 3, percent of the compound remaining: 6%
Beside the measured number, compound 3's estimate is 2 percentage points above it; measured number inside the range.
By their numbers in this assay, from the lowest: compounds 3, 2 and 1 (each within the scatter of the next).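

With hydrogen now at this spot, the position on the shared core has been seen with iodo, with fluoro and with no halogen at all. In this assay, replacing fluoro with hydrogen gives a number 1 percentage points lower from compound 2 to compound 3 (within the scatter), and replacing iodo with hydrogen gives a number 6 percentage points lower from compound 1 to compound 3 (within the scatter). The earlier pair compared only two halogens, whereas these steps show that removing the halogen altogether also leaves the compounds impossible to rank apart, so the choice among these three atoms makes no readable difference to the percent remaining. Nothing available explains why this spot has so little bearing on the read-out.

All three compounds keep only a small share of their starting amount, so the compounds shown leave open whether any group at this position could lift that number beyond the scatter. A group of a different kind here, such as an amine, a carboxylic acid or a longer carbon chain, might behave differently, and whether changes elsewhere on the shared core matter more also remains an open question.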